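Bromo to dichloro on the benzyl arm of the nucleoside series

This account rests on a few compounds, and the source may have more. Where it says the series, first, only, none or still open, it means among the compounds named here.

Working notes on a small nucleoside set. Compound 1 `OC[C@H]1O[C@@H](n2cnc3c(NCc4ccc(Cl)cc4)ncnc32)[C@H](O)[C@@H]1O` carries a chlorobenzyl group and in a functional assay on HL-60 cells (Homo sapiens) for antiproliferative activity, with a stated time of 72 h (on this read-out lower numbers stand for stronger inhibition and higher numbers for weaker inhibition), compound 1 gives 1700 nM. Within the data shown here, compound 2 `OC[C@H]1O[C@@H](n2cnc3c(NCc4ccc(Br)cc4)ncnc32)[C@H](O)[C@@H]1O` carries the bromo analogue and in this assay compound 2 gives 47400 nM, the highest number of the two measured, its nearest neighbour being compound 1 at the single step of a 28-fold higher number from compound 1 to compound 2 (1.45 log units; beyond the scatter).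

Compound 3 `OC[C@H]1O[C@@H](n2cnc3c(NCc4ccc(Cl)c(Cl)c4)ncnc32)[C@H](O)[C@@H]1O` is not yet measured. The change from compound 2 is 3,4-dichlorophenyl in place of 4-bromophenyl on a saturated chain carbon bound to a nitrogen on an aromatic ring. Among the measured compounds shown here, only one measured step bears on it, namely a 28-fold higher number from compound 1 to compound 2 (1.45 log units; beyond the scatter), which shows that chloro in place of bromo on this ring lowers the number strongly; no measured pair covers the second chlorine. Because of a 28-fold higher number from compound 1 to compound 2 (1.45 log units; beyond the scatter) the expected step in this assay is a large decrease, a 19-fold lower number from compound 2 to compound 3 (1.28 log units; beyond the scatter), with added uncertainty from the second chlorine. Compound 3 is therefore estimated at 2500 nM, within the range 500 nM to 15000 nM.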

Compound 3, half-maximal inhibitory concentration: 2000 nM
Beside the measured number, compound 3's estimate is 1.3-fold (0.10 log units) above it; the measured number falls inside the stated range.
By their numbers in this assay, from the lowest: compounds 1 and 3 (each within the scatter of the next); then compound 2.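

The step of a 1.2-fold higher number from compound 1 to compound 3 (0.07 log units; within the scatter) shows that in this assay the 3,4-dichlorobenzyl group cannot be told apart from the chlorobenzyl group of compound 1, so a second chlorine on this ring makes no readable difference. Among these compounds, the step of a 24-fold lower number from compound 2 to compound 3 (1.37 log units; beyond the scatter) leaves compound 2 as the only member of the three set apart, with both chlorinated compounds lying together at the lower end. Nothing measured on these compounds accounts for the separation of the bromo compound.

On these data alone, whether an unsubstituted benzyl, a fluorobenzyl or a methoxybenzyl group would fall with compound 1 and compound 3 or with compound 2 remains open. Also open, as far as these compounds go, is whether a 3,4-dibromobenzyl group would give a number like that of compound 2, which would test the bromo result on a second compound.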